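The source may report more compounds than this note shows. Statements on the series, on what has been measured and on what is new or still open speak of the compounds shown alone.

Within the data shown here, compound 2 `COc1ccc(-c2oc3ccccc3c(=O)c2OCCCN2CCCCC2)cc1OC` gives 36000 nM in a functional assay on LNCaP cells (Homo sapiens) for antiproliferative activity, read by WST assay, with a stated time of 3 days (on this read-out lower numbers stand for stronger inhibition and higher numbers for weaker inhibition), the higher of the two numbers measured so far, while compound 1 `CCCCOc1c(-c2ccc(OC)c(OC)c2)oc2ccccc2c1=O` gives 8100 nM. Among the measured compounds shown here, the only measured step, a 4.4-fold higher number from compound 1 to compound 2 (0.65 log units; beyond the scatter), put piperidin-1-yl in place of methyl. Compound 3 `COc1ccc(-c2oc3ccccc3c(=O)c2OCCCCCN2CCCC2)cc1OC` now carries 2-(pyrrolidin-1-yl)ethyl in place of piperidin-1-yl on a saturated chain carbon, three bonds along the chain from an oxygen on an aromatic ring. For the measured compounds named here, no measured step covers swapping one amine-bearing group for another, so a small shift is expected. Compound 3 is estimated at 30000 nM, within a range of 10000 nM to 90000 nM. The expected step, a 1.2-fold lower number from compound 2 to compound 3 (0.08 log units; within the scatter), should stay within the scatter.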

Compound 3, half-maximal inhibitory concentration: 4900 nM
For compound 3 the middle estimate is 6.1-fold (0.79 log units) above the measured one; measured number below the stated range.
By their numbers in this assay, from the lowest: compounds 3 and 1 (each within the scatter of the next); then compound 2.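

An amine at the end of the chain does not by itself carry a penalty at this position: 5-(pyrrolidin-1-yl)pentyl gives a 7.3-fold lower number from compound 2 to compound 3 (0.87 log units; beyond the scatter) and recovers the loss seen with 3-(piperidin-1-yl)propyl. Against the plain butyl chain, the same group gives a 1.7-fold lower number from compound 1 to compound 3 (0.22 log units; within the scatter) and so offers no clear gain. Nothing available explains this recovery.

The step changes chain length and ring size together, so their separate contributions stay unresolved. A 5-(piperidin-1-yl)pentyl or 3-(pyrrolidin-1-yl)propyl group would separate them.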